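Butyl in place of isopropyl on a cyclic phosphate

A few compounds are considered here, and "the series" means these few. Any claim that something is new, unique, unknown or untested is made for them only; others in the source may bear on it.

Compound 1, with the structure `CC(C)c1cn([C@H]2C[C@@H]3OP(=O)(O)OC[C@H]3O2)c(=O)[nH]c1=O`, carries an isopropyl group on its shared core, and its sugar part is closed into a cyclic phosphate. In a functional assay on L1210 cells (Mus musculus) (on this read-out lower numbers stand for stronger inhibition and higher numbers for weaker inhibition), compound 1 gives > 500 ug/mL, which is a limit of the assay rather than a number. A second compound, compound 2, with the structure `CCCCCCc1cn([C@H]2C[C@H](O)[C@@H](CO)O2)c(=O)[nH]c1=O`, has a hexyl chain on the same kind of core but an open sugar with free hydroxyl groups; in this assay compound 2 gives 172 ug/mL. Within the data shown here, no step between these two measured compounds is given, so their two values can only be set side by side.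

The unmeasured compound 3, with the structure `CCCCc1cn([C@H]2C[C@@H]3OP(=O)(O)OC[C@H]3O2)c(=O)[nH]c1=O`, keeps the cyclic phosphate of compound 1 and differs only by butyl in place of isopropyl on an aromatic carbon. Since compound 1 sits at the limit, as shown by the limit of > 500 ug/mL in this assay, at which 1 of the 2 values shown sits, no numerical starting point is known, and a step from compound 1 to compound 3 of no more than the usual scatter is expected. For compound 3 the value in this assay is estimated as 500 ug/mL, within 200 ug/mL to 1500 ug/mL, meaning an expected step of a number no higher from compound 1 to compound 3 (the limit leaves the size open).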

Compound 3, concentration for 50% inhibition: 28.4 ug/mL
The estimate for compound 3 lay 18-fold (1.25 log units) above the measured number; the whole stated range lies above it.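

On the cyclic phosphate, this position turns out to be sensitive to which carbon chain it carries: in this assay, butyl in place of isopropyl on the aromatic carbon gives an at least 17-fold lower number from compound 1 to compound 3 (1.24 log units; beyond the scatter). This is a large step for a change between two plain carbon groups, neither of which has a ring or a net charge. Its full size cannot be stated, however, because compound 1 stands at a limit and not at a number: the limit of > 500 ug/mL in this assay, at which 1 of the 3 values shown sits.

With only this one step to read, the compounds shown do not tell whether the lower number follows from the greater length of butyl or from its replacing the branched isopropyl, and compound 2 cannot settle this, as it differs from compound 3 in the sugar part as well as in the chain. Also open, going by these compounds, is how this assay would respond on the same cyclic phosphate to a longer chain such as octyl, or to a butyl chain ending in an amine or a carboxylic acid.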